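The source may report more compounds than this note shows. Statements on the series, on what has been measured and on what is new or still open speak of the compounds shown alone.

Measured so far:
Compound 1 `CCCCN(CC)c1nc(C)nc2c(-c3ccc(OC)nc3C)c(C)nn12` — in an assay on cell membranes for displacement of a labelled ligand from corticotropin-releasing factor receptor 1 (Rattus norvegicus) (on this read-out higher numbers stand for weaker inhibition and lower numbers for stronger inhibition), compound 1 gives 4.9 nM.
Compound 2 `CCCCN(C)c1nc(C)nc2c(-c3ccc(OC)nc3C)c(C)nn12` — in this assay compound 2 gives 8.1 nM.
Compound 3 `CCCN(CCC)c1nc(C)nc2c(-c3ccc(OC)nc3C)c(C)nn12` — in this assay compound 3 gives 5.7 nM.

All three compounds share one core and differ only in the two alkyl groups carried by the amino nitrogen. Among these three numbers compound 3 sits with the others: one step is a 1.2-fold higher number from compound 1 to compound 3 (0.07 log units; within the scatter), and the other step is a 1.4-fold lower number from compound 2 to compound 3 (0.15 log units; within the scatter), so nothing separates the three beyond the usual scatter.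

Compound 4 `CCC[C@H](C)Nc1nc(C)nc2c(-c3ccc(OC)nc3C)c(C)nn12` is the next step from compound 3: (1-methylbutyl)amino in place of dipropylamino on an aromatic carbon. The amino nitrogen thus loses one of its two chains and gains a hydrogen, while the remaining chain carries a branch with a defined stereocentre.

Every measured step bears on this only in part. The steps of a 1.7-fold higher number from compound 1 to compound 2 (0.22 log units; within the scatter), a 1.2-fold higher number from compound 1 to compound 3 (0.07 log units; within the scatter) and a 1.4-fold lower number from compound 2 to compound 3 (0.15 log units; within the scatter) show that trading one alkyl chain for another on this nitrogen left the numbers unchanged within the scatter. Going by the values given here, no measured pair, however, tests a nitrogen bearing a hydrogen, so the change in compound 4 reaches beyond what the three steps cover. The expectation is therefore a small step, a 1.4-fold higher number from compound 3 to compound 4 (0.15 log units; within the scatter), with room for a somewhat higher number.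

Compound 4 is estimated at 8 nM, expected between 3 nM and 25 nM.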

Compound 4, half-maximal inhibitory concentration: 4.5 nM
Beside the measured number, compound 4's estimate is 1.8-fold (0.25 log units) above it, within the range that was stated.
By their numbers in this assay, from the lowest: compounds 4, 1, 3 and 2 (each within the scatter of the next).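

Compound 4 shows that the amino nitrogen on this aromatic carbon, between two ring nitrogen atoms, does not need two alkyl chains in this assay. Moving to (1-methylbutyl)amino, which brings a hydrogen-bond donor and a defined stereocentre, gives a 1.3-fold lower number from compound 3 to compound 4 (0.10 log units; within the scatter) and a 1.8-fold lower number from compound 2 to compound 4 (0.26 log units; within the scatter) and a 1.1-fold lower number from compound 1 to compound 4 (0.04 log units; within the scatter) as steps that leave compound 4 level with the earlier compounds. Going by these compounds alone, the earlier steps only traded one alkyl chain for another on a nitrogen without a hydrogen, so this is the first sign that a nitrogen bearing a hydrogen and a single branched chain also fits here, though no measurement available explains why the numbers hold so steady.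

The change to compound 4 alters the hydrogen on the nitrogen, the branching and the stereocentre all at once, so the compounds shown cannot say how much each contributes, and the mirror-image form of the 1-methylbutyl group remains an open comparison. Also open, as far as these compounds go, is how far this tolerance extends to other groups on the nitrogen, such as a cyclopropylmethyl or a 2-methoxyethyl chain.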